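Trimming a Urea Side Chain to a Plain Carbamate

This account rests on a few compounds, and the source may have more. Where it says the series, first, only, none or still open, it means among the compounds named here.

Compound 1 `CCOC(=O)CNC(=O)NC1=CS(=O)(=O)O[C@@]12[C@@H](CO[Si](C)(C)C(C)(C)C)O[C@@H](n1cc(C)c(=O)n(C)c1=O)[C@@H]2O[Si](C)(C)C(C)(C)C` was tested in a functional assay on MT4 cells (Homo sapiens) (a lower number here means that less compound is tolerated, a higher number that more compound is tolerated), where compound 1 gives 3780 nM. This is the lowest of the two values reported as numbers; compound 3 `Cc1cn([C@@H]2O[C@@H]3COC4(O)CS(=O)(=O)O[C@@]34[C@H]2O)c(=O)[nH]c1=O` gives 100000 nM, and that gap lies beyond the usual scatter. Compound 2 `Cc1cn([C@@H]2O[C@@H]3COC(=O)[C@]3(OS(C)(=O)=O)[C@H]2O)c(=O)[nH]c1=O` reaches only a limit of the assay, >= 250000 nM; the record notes (the limit of >= 250000 nM in this assay, at which 1 of the 3 values shown sits). Compound 4 `COC(=O)NC1=CS(=O)(=O)O[C@@]12[C@@H](CO[Si](C)(C)C(C)(C)C)O[C@@H](n1cc(C)c(=O)n(C)c1=O)[C@@H]2O[Si](C)(C)C(C)(C)C` has not yet been measured. It differs from compound 1 in one place: methoxy in place of ((ethoxycarbonyl)methyl)amino on a carbonyl carbon. Within the data shown here, no measured pair shows the effect of such a change, so the expectation rests on compound 1 alone. A small step toward a higher number, within the scatter, is expected, a 1.3-fold higher number from compound 1 to compound 4 (0.12 log units; within the scatter). Compound 4 is thus estimated at 5000 nM, with a range from 1500 nM to 20000 nM.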

Compound 4, half-maximal cytotoxic concentration: 29900 nM
Beside the measured number, compound 4's estimate is 6.0-fold (0.78 log units) below it, and the stated range ends below it.
By their numbers in this assay, from the lowest: compound 1; then compound 4; then compound 3. At a limit, above all of these: compound 2.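

Swapping ((ethoxycarbonyl)methyl)amino for methoxy on this carbonyl carbon is a change that this assay can detect, giving a 7.9-fold higher number from compound 1 to compound 4 (0.90 log units; beyond the scatter). With the rest of the structure unchanged, more compound is tolerated after this side chain is trimmed, so the side chain contributes to the value of compound 1. Nothing in the data shown explains the size of this step.

Going by these compounds, it remains open whether ethoxy, a simple amine or a carboxylic acid on the same carbonyl carbon would move the number in the same direction. This single pair also cannot show whether the step would hold on a different core.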